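Compound 3 to compound 4: exchange of the aromatic group

A few compounds are considered here, and "the series" means these few. Any claim that something is new, unique, unknown or untested is made for them only; others in the source may bear on it.

In a functional assay on HeLa cells (Homo sapiens) for cytotoxicity, read by MTT assay, with a stated time of 48 h (a lower number here means a stronger inhibitor, a higher number a weaker inhibitor), compound 1 (`C=C1CCC[C@]2(C)CCC(C=O)=CC[C@@]12C`) stands at 191000 nM and compound 2 (`C#CC1=CC[C@@]2(C)C(=C)CCC[C@]2(C)CC1`) at 158000 nM while compound 3 (`C=C1CCC[C@]2(C)CCC(c3cn(-c4ccc(OC)cc4)nn3)=CC[C@@]12C`) gives 43600 nM as the lowest of the three numbers, with its gaps to both others beyond the scatter. Compound 4 (`C=C1CCC[C@]2(C)CCC(c3cn(-c4cccc([N+](=O)[O-])c4)nn3)=CC[C@@]12C`) has 3-nitrophenyl in place of 4-methoxyphenyl on an aromatic nitrogen and otherwise matches compound 3.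

Among the compounds with values here, the only measured step (a 1.2-fold lower number from compound 1 to compound 2 (0.08 log units; within the scatter)) is ethynyl in place of formyl on a double-bonded ring carbon. It lies within the scatter and does not touch this aromatic nitrogen. Within the data shown here, no measured pair varies the group there, so the size of this exchange is unknown. Among the measured compounds shown here, compound 3 is also the only measured compound with such a group, and its gaps to compound 1 and compound 2 cannot be assigned to the 4-methoxyphenyl alone.

For the measured compounds named here, with that single step (a 1.2-fold lower number from compound 1 to compound 2 (0.08 log units; within the scatter)) as the only guide, no step beyond the scatter is expected in this assay in either direction. The estimated step (a 1.1-fold lower number from compound 3 to compound 4 (0.04 log units; within the scatter)) stays within the scatter, with wide uncertainty. Compound 4 is estimated at 40000 nM within an expected range from 17000 nM to 90000 nM for now.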

Compound 4, half-maximal inhibitory concentration: 31900 nM
Estimate against measurement, compound 4: 1.3-fold (0.10 log units) above, within the range that was stated.
By their numbers in this assay, from the lowest: compounds 4 and 3 (each within the scatter of the next); then compounds 2 and 1 (each within the scatter of the next).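

In this assay, within the data shown here, the exchange on the aromatic nitrogen of the five-membered aromatic ring gives the first measured step at this position: a 1.4-fold lower number from compound 3 to compound 4 (0.14 log units; within the scatter). Within this pair, 3-nitrophenyl and 4-methoxyphenyl cannot be told apart, although the exchange alters both the substituent and its numbered place on the phenyl ring, so this position accepts this particular change with no readable shift in this assay. No measurement is available that could explain this result.

With both features changing together, the pair cannot show whether each alone would leave the number unchanged or whether two separate contributions happen to offset each other; 4-nitrophenyl or 3-methoxyphenyl on the same nitrogen would separate them. Also open, going by these compounds, is whether a step beyond the scatter can be reached at this position at all, for example with unsubstituted phenyl, benzyl, a longer alkyl chain, or an aryl group carrying an amine or a carboxylic acid.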